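This account rests on a few compounds, and the source may have more. Where it says the series, first, only, none or still open, it means among the compounds named here.

In a functional assay on LS174T cells (Homo sapiens) for antiproliferative activity, with a stated time of 4 days (on this read-out lower numbers stand for stronger inhibition and higher numbers for weaker inhibition), compound 1 `CN(C)c1ccc(C#Cc2ccccc2F)cc1` gives 39 nM. Compound 2 `CN(C)c1ccc(C#Cc2cccc(F)c2)cc1` stands only at a limit of this assay, > 3000 nM, as shown by the limit of > 3000 nM in this assay, at which 1 of the 2 values shown sits. Compound 3 `CN(C)c1ccc(C#Cc2cc(F)ccc2F)cc1` differs from compound 2 by fluoro in place of hydrogen on an aromatic carbon. Within the data shown here, no measured step between two compounds that share this change is available, and the two values shown do not fix its size. The step of an at least 10-fold lower number from compound 2 to compound 3 (1.00 log units; beyond the scatter) is expected to give stronger inhibition, well beyond the scatter. Compound 3 is estimated at 300 nM, with a range from 30 nM to 3000 nM.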

Compound 3, half-maximal inhibitory concentration: 55 nM
Compound 3: middle estimate off by 5.5-fold (0.74 log units), on the high side, within the range that was stated.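

In this assay fluoro in place of hydrogen, ortho to a large group and para to a fluoro group, gives an at least 54-fold lower number from compound 2 to compound 3 (1.73 log units; beyond the scatter) and so marks this place as decisive for this pair. Compound 2 stands at a limit of the assay, so the size of that step is itself only a limit: the limit of > 3000 nM in this assay, at which 1 of the 3 values shown sits. Adding the other fluoro instead gives a 1.4-fold higher number from compound 1 to compound 3 (0.15 log units; within the scatter) and shows that the low number goes with fluoro at this place, with or without the second fluoro.

On these data alone, whether chloro, methoxy or an amine at this place would serve as fluoro does stays open. So does whether any other group there would keep the number low.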